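The source may report more compounds than this note shows. Statements on the series, on what has been measured and on what is new or still open speak of the compounds shown alone.

In an ADME assay on Vero cells (Chlorocebus sabaeus) for cytotoxicity, read by MTT assay (a higher number here means that more compound is tolerated, a lower number that less compound is tolerated), compound 1 (`Cn1nc(C(F)(F)F)cc1C(=O)Nc1ccc(S(=O)(=O)N2CCC[C@H]2C(=O)O)cc1`) gives > 300000 nM, a limit of the assay. Compound 2 (`Cn1nc(C(F)(F)F)cc1C(=O)Nc1ccc(S(=O)(=O)N2CCOCC2)cc1`) gives > 300000 nM, also a limit. Compound 3 (`Cn1nc(C(F)(F)F)cc1C(=O)Nc1ccc(S(=O)(=O)N2CCC(NC(=O)OC(C)(C)C)CC2)cc1`) stands at > 300000 nM, again a limit and not a number. Among the measured compounds shown here, the series so far sits at one point: the limit of > 300000 nM in this assay, at which 3 of the 3 values shown sit.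

Compound 4 (`Cn1nc(C(F)(F)F)cc1C(=O)Nc1ccc(S(=O)(=O)N2CCC(N)CC2)cc1`) differs from compound 3 by one change: hydrogen in place of tert-butoxycarbonyl on an amine nitrogen. In short, hydrogen takes the place of tert-butoxycarbonyl on an amine nitrogen, so (tert-butoxycarbonyl)amino becomes amino.

For the measured compounds named here, the only measured step that can bear on this is a step that the two limits leave unreadable from compound 1 to compound 2. It has no readable size, so it offers no magnitude to carry over, and it concerns a different change. With nothing measured to suggest otherwise, no step beyond the scatter is expected in this assay. The expected outcome is a number no higher from compound 3 to compound 4 (the limit leaves the size open), and this remains an estimate. Compound 4 is estimated at 300000 nM, with an expected range from 120000 nM to 600000 nM.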

Compound 4, half-maximal cytotoxic concentration: > 300000 nM
Compound 4 gave a limit, no number; the forecaster's own chance of this, stated with the estimate: 65%; the middle value lies on the limit itself.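

In this assay compound 4 gives > 300000 nM, a limit and not a number; its steps from compound 1, compound 2 and compound 3 cannot be read. The compounds shown leave open at what concentration any of them becomes cytotoxic, the series resting at one point: the limit of > 300000 nM in this assay, at which 4 of the 4 values shown sit.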